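Working notes: adding methoxy to compound 1

A few compounds are considered here, and "the series" means these few. Any claim that something is new, unique, unknown or untested is made for them only; others in the source may bear on it.

compound 1 `COc1cc(/C=C/C(=O)O)ccc1OC(=O)c1nc(C)c(C)nc1C` gives 69400 nM
compound 2 `CCOC(=O)/C=C/c1ccc(OC)cc1OC(=O)c1nc(C)c(C)nc1C` gives 138000 nM
compound 3 `CCOC(=O)/C=C/c1ccc(OC(=O)c2nc(C)c(C)nc2C)c(O)c1` gives 1700 nM

For the measured compounds named here, all three values come from a functional assay on EA.hy 926 cells (Homo sapiens) for cytotoxicity, read by MTT assay, with stated times of 24 h and 12 h (a higher number here means that more compound is needed for the effect, a lower number that less compound is needed), and form the whole of the measured series so far. Compound 1 and compound 2 lie within the scatter of each other, so no order is read between them. Compound 3 lies beyond the scatter from compound 1, at a clearly lower number, which leaves compound 1 at the high end of the three together with compound 2.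

The next compound is compound 4 `COc1cc(/C=C/C(=O)O)cc(OC)c1OC(=O)c1nc(C)c(C)nc1C`, which differs from compound 1 by one change (methoxy in place of hydrogen on an aromatic carbon) namely methoxy in place of hydrogen on an aromatic carbon. Going by the values given here, no measured pair isolates this change. In this assay no step beyond the scatter is expected. This expectation rests on compound 2 (138000 nM) which also carries a methoxy group and stays within the scatter of compound 1 (69400 nM) in the same assay. Compound 3 (1700 nM) goes against any flat picture of the series, so the range is kept wide. The expected step of a 1.1-fold lower number from compound 1 to compound 4 (0.03 log units; within the scatter) is estimated to be small. For compound 4 the estimated value is 65000 nM with an expected range from 15000 nM to 200000 nM in this assay.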

Compound 4, half-maximal effective concentration: 34700 nM
Compound 4: the middle estimate sits 1.9-fold (0.27 log units) above what was measured, within the range that was stated.
By their numbers in this assay, from the lowest: compound 3; then compounds 4, 1 and 2 (each within the scatter of the next, the first and the last beyond it).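

In this assay, for the compounds shown here, compound 4 and compound 1 form the first measured pair that isolates methoxy in place of hydrogen on an aromatic carbon, and the pair gives a 2.0-fold lower number from compound 1 to compound 4 (0.30 log units; within the scatter), so no order is read between the two compounds. This gives a direct reading for this position, ortho to a large group and meta to both the 2-carboxyethenyl group and the existing methoxy group: a second methoxy group is accommodated here without a step beyond the scatter. The reading holds for this one position and this one substituent, with the free carboxylic acid kept in place, and no measurement at hand explains the size of the step.

Still open, from the compounds shown here alone, is how the same position responds to a different group, such as an amine, a hydroxy group or a longer chain such as ethoxy. Going by these compounds alone, also open is whether methoxy at this position gives a similar step in a compound carrying the ethyl ester of compound 2 and compound 3 in place of the carboxylic acid, since no measured pair tests this.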